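This account rests on a few compounds, and the source may have more. Where it says the series, first, only, none or still open, it means among the compounds named here.

Measured compounds:
compound 1 `CCN(Cc1ccccc1)C(=O)C1CCN(S(=O)(=O)c2ccc(C)s2)CC1`: 64%
compound 2 `CCN(Cc1ccccc1)C(=O)C1CCN(S(=O)(=O)c2ccc3occc3c2)CC1`: 80%

In a functional assay on CHO cells for positive allosteric modulation of muscarinic acetylcholine receptor M5 (Homo sapiens), read by calcium flux (on this read-out lower numbers stand for smaller maximal responses and higher numbers for larger maximal responses), compound 2 gives 80%, the highest of the two numbers; compound 1 gives 64%. Among the measured compounds shown here, the single measured step is a number 16 percentage points higher from compound 1 to compound 2 (beyond the scatter), a modest gain on replacing a five-membered heteroaryl with a fused bicyclic aryl on the sulfonyl sulfur.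

Compound 3 `CCN(Cc1ccccc1)C(=O)C1CCN(S(=O)(=O)c2ccc3cn[nH]c3c2)CC1` differs from compound 2 by 1H-indazol-6-yl in place of 1-benzofuran-5-yl on a sulfonyl sulfur. For the measured compounds named here, no measured step exchanges one fused bicycle for another on the sulfonyl sulfur, so the only step bears on this change indirectly: it shows that the group on the sulfonyl sulfur can move the maximal response in this assay, but not in which direction a change from benzofuranyl to indazolyl would go. A step of a number 8 percentage points lower from compound 2 to compound 3 (within the scatter) is expected, within or near the scatter. Compound 3 is estimated at 72%, in the range 52% to 90%.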

Compound 3, largest response reached (reported as percent of maximum), in percent of the reference or control that the assay uses: 86%
Compound 3: the middle estimate sits 14 percentage points below what was measured, within the range that was stated.
By their numbers in this assay, from the lowest: compound 1; then compounds 2 and 3 (each within the scatter of the next).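

At the sulfonyl sulfur, in this assay, exchanging one fused bicycle for another gives a number 6 percentage points higher from compound 2 to compound 3 (within the scatter), so this read-out does not separate 1H-indazol-6-yl from 1-benzofuran-5-yl, although only the former carries a hydrogen-bond donor. The second comparison, a number 22 percentage points higher from compound 1 to compound 3 (beyond the scatter), places a second fused bicycle clear of 5-methylthiophen-2-yl, so among these three compounds both fused bicycles stand beyond the scatter from the single five-membered ring, with no compound going against this. Nothing available on these compounds accounts for either step.

The compounds shown leave open whether an unfused phenyl or pyridyl group on the sulfonyl sulfur would keep the maximal response seen with the fused bicycles. They also leave open how the response depends on the ethyl and benzyl groups on the amide nitrogen, which stay the same throughout.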